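This account rests on a few compounds, and the source may have more. Where it says the series, first, only, none or still open, it means among the compounds named here.

The series shares one core, varied on a nitrogen on the aromatic ring. Compound 1 `CS(=O)(=O)NNc1nonc1/C(=N/O)Nc1ccc(F)c(Br)c1`, compound 2 `CN(C)S(=O)(=O)CCNc1nonc1/C(=N/O)Nc1ccc(F)c(Br)c1` and compound 3 `O=S(=O)(CCNc1nonc1/C(=N/O)Nc1ccc(F)c(Br)c1)NCC1CC1` have been measured in an assay on HeLa cells for inhibition of Indoleamine 2,3-dioxygenase 1 (Homo sapiens), read by spectrophotometry, with a stated time of 24 h; a lower number here means that less compound is needed, a higher number that more compound is needed for the effect. In this assay compound 1 gives > 800 nM, which is a limit of the assay rather than a number (the limit of > 800 nM in this assay, at which 1 of the 3 values shown sits). Compound 2 gives 17 nM, and the step of an at least 47-fold lower number from compound 1 to compound 2 (1.67 log units; beyond the scatter) is the largest shown. Compound 3 gives 268 nM, the highest of the two numbers shown; its nearest neighbour is compound 2, the step being a 16-fold higher number from compound 2 to compound 3 (1.20 log units; beyond the scatter).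

Compound 4 `CN(C)S(=O)(=O)CCCNc1nonc1/C(=N/O)Nc1ccc(F)c(Br)c1` is not yet measured. Against compound 3 the change is (dimethylsulfamoyl)methyl in place of (cyclopropylmethyl)sulfamoyl on a saturated chain carbon, two bonds along the chain from a nitrogen on an aromatic ring; compound 4 thus carries a dimethylsulfamoyl group, as compound 2 does, but on an extended chain. The step of a 16-fold higher number from compound 2 to compound 3 (1.20 log units; beyond the scatter) bears on it directly and in reverse: returning to dimethylamino on the sulfonyl sulfur should give a lower number. Among the compounds with values here, the chain extension has no measured counterpart in this set. Compound 4 is therefore expected at 40 nM, between 10 nM and 160 nM, an expected step of a 6.7-fold lower number from compound 3 to compound 4 (0.83 log units; beyond the scatter) that should fall beyond the scatter.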

Compound 4, half-maximal effective concentration: 20 nM
Compound 4: the middle estimate sits 2.0-fold (0.30 log units) above what was measured, and the stated range covers the measured number.
By their numbers in this assay, from the lowest: compounds 2 and 4 (each within the scatter of the next); then compound 3. At a limit, above all of these: compound 1.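

With the dimethylsulfamoyl group kept, the two chain lengths cannot be told apart in this assay: a 1.2-fold higher number from compound 2 to compound 4 (0.07 log units; within the scatter), so this position accepts 3-(dimethylsulfamoyl)propyl as readily as the 2-(dimethylsulfamoyl)ethyl of compound 2. The step of a 13-fold lower number from compound 3 to compound 4 (1.13 log units; beyond the scatter) combines the chain length with the group on the sulfonyl sulfur, yet it agrees with compound 2 in leaving compound 3, the only (cyclopropylmethyl)sulfamoyl compound, with the higher number. The step of an at least 40-fold lower number from compound 1 to compound 4 (1.60 log units; beyond the scatter) rests on a limit of the assay and not on a number: the limit of > 800 nM in this assay, at which 1 of the 4 values shown sits.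

On these data alone, whether a still longer chain, such as a butyl linker, keeps the number of compounds 2 and 4 remains open. As far as these compounds go, it is also open whether a methylamino or morpholine group on the sulfonyl sulfur stays with them or moves towards compound 3.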